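Methyl for bromo on the shared core

The source may report more compounds than this note shows. Statements on the series, on what has been measured and on what is new or still open speak of the compounds shown alone.

Compound 3 `CC(NC(=O)NS(=O)(=O)c1ccccc1)c1cc(Br)ccc1OCc1ccccc1` gives 130000 nM in a functional assay on thoracic aorta (Rattus norvegicus, strain Wistar), with a stated time of 15 min (on this read-out higher numbers stand for an effect only at larger amounts of compound and lower numbers for an effect already at smaller amounts), and stands at the top of the three numbers shown, within the scatter of compound 1 and beyond it only against compound 2. Compound 1 `Cc1ccc(OCc2ccccc2)c(C(C)NC(=O)NS(=O)(=O)c2ccc(Cl)cc2)c1` gives 65300 nM and compound 2 `CC(NC(=O)N(C)S(=O)(=O)c1ccccc1)c1cc(Br)ccc1OCc1ccccc1` gives 60300 nM. For the measured compounds named here, the one single-point step measured is a 2.2-fold higher number from compound 2 to compound 3 (0.33 log units; beyond the scatter), which does not touch the aromatic ring. Compound 4 `Cc1ccc(OCc2ccccc2)c(C(C)NC(=O)NS(=O)(=O)c2ccccc2)c1` differs from compound 3 by methyl in place of bromo on an aromatic carbon. Going by the values given here, no measured step bears on this change; compound 1 carries the same methyl but also a chloro group on the other ring, and its number against compound 3 lies within the scatter. For compound 4 the step of a 1.3-fold lower number from compound 3 to compound 4 (0.11 log units; within the scatter) is therefore expected to stay within the scatter. Compound 4 is estimated at 100000 nM, with a range from 40000 nM to 250000 nM.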

Compound 4, half-maximal effective concentration: > 200000 nM
Compound 4: a limit, no number; the forecaster's own chance of this, stated with the estimate: 20%; at least 2.0-fold (0.30 log units) between middle value and limit.
By their numbers in this assay, from the lowest: compounds 2, 1 and 3 (each within the scatter of the next, the first and the last beyond it). At a limit, above all of these: compound 4.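

In this assay compound 4 stands at a limit, not a number: the limit of > 200000 nM in this assay, at which 1 of the 4 values shown sits.

Methyl in place of bromo, para to a benzyloxy group, gives an at least 1.5-fold higher number from compound 3 to compound 4 (0.18 log units; that floor lies within the scatter), so only a floor is known for this change. Hydrogen in place of chloro on an aromatic carbon, with the methyl kept, gives an at least 3.0-fold higher number from compound 1 to compound 4 (0.48 log units; beyond the scatter), the first change on an aromatic ring that reads beyond the scatter.

Open, going by these compounds, is what an amine or a carboxylic acid would give in place of bromo. Also open, on these data alone, is whether methyl on the amide-type nitrogen repeats its step on the methyl-bearing core.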